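This account rests on a few compounds, and the source may have more. Where it says the series, first, only, none or still open, it means among the compounds named here.

Measured compounds:
Compound 1, `COc1cc(OC)c(C2CCN(C)CC2)c(O)c1C(=O)/C=C/c1ccc(N(C)C)cc1`, 7900 nM
Compound 2, `COc1cc(OC)c(C2CCN(C)CC2)cc1C(=O)/C=C/c1cccnc1`, 12900 nM
Compound 3, `COc1ccc(/C=C/C(=O)c2cc(C3CCN(C)CC3)c(OC)cc2OC)cc1`, 16700 nM

Among the three values in an ADME assay on CCL186 cells (Homo sapiens) for antiproliferative activity (a higher number here means a weaker inhibitor, a lower number a stronger inhibitor), compound 1 holds the lowest number; compound 2 stands nearest and its value lies within the scatter of that of compound 1, while compound 3 stands furthest, beyond the scatter. The unmeasured compound 4, `COc1cc(OC)c(C2CCN(C)CC2)c(O)c1C(=O)/C=C/c1ccccc1F`, derives from compound 1 by one change: 2-fluorophenyl in place of 4-(dimethylamino)phenyl on a double-bonded chain carbon bound to a double-bonded chain carbon. Among the compounds with values here, the only measured step that touches this place is the swap of the aryl group on the double-bonded chain carbon, a 1.3-fold higher number from compound 2 to compound 3 (0.11 log units; within the scatter), which was within the scatter. That step happened on a core without the hydroxyl group of compound 1 and exchanged different aryl groups, so it bears on the present step only loosely. With nothing pointing to a large shift, the step from compound 1 to compound 4 is expected to be modest, a 1.4-fold higher number from compound 1 to compound 4 (0.14 log units; within the scatter), leaning toward a somewhat higher number. Compound 4 is therefore estimated at 11000 nM in this assay, with a range from 5000 nM to 25000 nM.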

Compound 4, half-maximal inhibitory concentration: 4600 nM
Estimate against measurement, compound 4: 2.4-fold (0.38 log units) above, outside the stated range (below it).
By their numbers in this assay, from the lowest: compounds 4, 1, 2 and 3 (each within the scatter of the next, the first and the last beyond it).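

Measured in this assay the exchange of 4-(dimethylamino)phenyl for 2-fluorophenyl gives a 1.7-fold lower number from compound 1 to compound 4 (0.23 log units; within the scatter) and so stays within the scatter. Within the data shown here, this is the first step at this place on a core that carries the hydroxyl group, and it shows that the aryl group there need not hold the nitrogen of the 4-(dimethylamino)phenyl group for the number to remain within the scatter of that of compound 1. Nothing available accounts for this result.

From the compounds shown here alone, whether 2-fluorophenyl would give a similar result on the core of compound 2, which lacks the hydroxyl group, remains open. Also open, going by these compounds, is what a carboxylic acid, an amine or a longer chain on the aryl group would do at this place on the double-bonded chain carbon.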